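The compounds below may be only part of what the source reports. "The series", "measured", "known", "first", "only" and "open" are said of these compounds alone.

Three compounds share one core and differ only in the group attached through a chain carbon to a ring nitrogen. In a functional assay on HCT-116 cells (Homo sapiens) for inhibition, read by sulforhodamine B assay, with a stated time of 48 h (a lower number here means a stronger inhibitor of growth, a higher number a weaker inhibitor of growth), compound 1 `Nc1cc(N)c2nc(-c3ccccc3)c(NCc3ccc(Cl)c(Cl)c3)nc2c1` gives 24000 nM. Compound 3 `COc1ccc(CNc2nc3cc(N)cc(N)c3nc2-c2ccccc2)cc1` gives 27500 nM in this assay, a step of a 1.1-fold higher number from compound 1 to compound 3 (0.06 log units; within the scatter). Compound 2 `Nc1cc(N)c2nc(-c3ccccc3)c(NCc3ccc(F)cc3)nc2c1` gives only a limit of the assay in this assay, < 100000 nM. Because of the limit of < 100000 nM in this assay, at which 1 of the 3 values shown sits, the steps a step that the limit leaves unreadable from compound 1 to compound 2 and a step that the limit leaves unreadable from compound 2 to compound 3 stay unreadable, so compound 2 stands at a limit and not at a known number. Compound 4 `Nc1cc(N)c2nc(-c3ccccc3)c(Oc3ccc(F)cc3)nc2c1` carries 4-fluorophenoxy in place of (4-fluorobenzyl)amino on an aromatic carbon. Among the measured compounds shown here, no measured step bears on this change, and both steps reaching compound 2 are unreadable, so no step beyond the scatter is expected in either direction. Compound 4 is expected to give about 40000 nM, within 10000 nM to 150000 nM. That amounts to an expected step that the limit leaves unreadable from compound 2 to compound 4.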

Compound 4, concentration for total growth inhibition: 81300 nM
Compound 4: the middle estimate sits 2.0-fold (0.31 log units) below what was measured; the measured number falls inside the stated range.
By their numbers in this assay, from the lowest: compounds 1 and 3 (each within the scatter of the next); then compound 4.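

No new step can be read from compound 2 to compound 4, because compound 2 gives a limit and not a number: the limit of < 100000 nM in this assay, at which 1 of the 4 values shown sits.

The compounds shown leave open how 4-fluorophenoxy compares with (4-fluorobenzyl)amino on the shared core in this assay.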